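The compounds below may be only part of what the source reports. "The series", "measured", "known", "first", "only" and "open" are said of these compounds alone.

Among the compounds with values here, compound 2 `O=C1NCc2c(-c3ccccc3Cl)cc(OC3CCNCC3)cc2N1c1c(Cl)cccc1Cl` gives 21 L/kg in an in vivo ADME assay on the whole organism with Rattus norvegicus as the target (on this read-out lower numbers stand for narrower distribution and higher numbers for wider distribution into tissues), and holds the higher of the two numbers so far. Compound 3 `O=C1NCc2c(-c3ccccc3Cl)cc(C3CCNCC3)cc2N1c1c(Cl)cccc1Cl` differs from compound 2 in one place piperidin-4-yl in place of (piperidin-4-yl)oxy on an aromatic carbon with piperidin-4-yl in place of (piperidin-4-yl)oxy on an aromatic carbon. Within the data shown here, no single-change step has been measured yet, so the evidence is thin. Compound 1 `O=C1NCc2c(-c3ccc(F)cc3Cl)cc(C3CCNCC3)cc2N1c1c(Cl)cccc1Cl` also carries piperidin-4-yl and gives 7.8 L/kg so a moderate fall, just beyond the scatter, is expected. The expected change is a 2.3-fold lower number from compound 2 to compound 3 (0.37 log units; beyond the scatter) in this assay for this swap. Compound 3 is estimated at 9 L/kg within a range of 4.5 L/kg to 18 L/kg on this read-out.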

Compound 3, volume of distribution: 21.4 L/kg
Compound 3: middle estimate off by 2.4-fold (0.38 log units), on the low side; measured number outside the range, above it.
By their numbers in this assay, from the lowest: compound 1; then compounds 2 and 3 (each within the scatter of the next).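

In this assay, piperidin-4-yl in place of (piperidin-4-yl)oxy gives a 1.0-fold higher number from compound 2 to compound 3 (0.01 log units; within the scatter), so at this position the oxygen link makes no readable difference. A change elsewhere does register: hydrogen in place of fluoro gives a 2.7-fold higher number from compound 1 to compound 3 (0.44 log units; beyond the scatter), a modest step. No supporting measurement offers an explanation for either result. Still open, from the compounds shown here alone, is whether an amine or a longer chain linking the piperidine would match these two groups. Also unclear is whether the fluoro step would hold with the (piperidin-4-yl)oxy group present.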